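The source may report more compounds than this note shows. Statements on the series, on what has been measured and on what is new or still open speak of the compounds shown alone.

Two ureas share one core and differ only in the aromatic group on the amide-type nitrogen. In an assay on isolated protein for inhibition of Fatty-acid amide hydrolase 1 (Homo sapiens), with a stated time of 60 min (a higher number here means a weaker inhibitor, a lower number a stronger inhibitor), compound 1 `O=C(Nc1cccc2nonc12)N1CCN(Cc2cccc(Oc3ccc(Cl)cc3)c2)CC1` gives 28 nM, and compound 2 `O=C(Nc1cncc2ccccc12)N1CCN(Cc2cccc(Oc3ccc(Cl)cc3)c2)CC1` gives 6.7 nM. For the measured compounds named here, the step of a 4.2-fold lower number from compound 1 to compound 2 (0.62 log units; beyond the scatter) is the only measured step, and on these two numbers compound 2 stands lowest. Compound 3 `O=C(Nc1noc2ccccc12)N1CCN(Cc2cccc(Oc3ccc(Cl)cc3)c2)CC1` differs from compound 2 in one place: a group of 9 heavy atoms (7 carbon, 1 nitrogen, 1 oxygen; one five-membered aromatic ring with 2 hetero atoms, one six-membered aromatic ring of carbon only) in place of a group of 10 heavy atoms (9 carbon, 1 nitrogen; one six-membered aromatic ring of carbon only, one six-membered aromatic ring with 1 hetero atom), on an amide-type nitrogen. The step from compound 1 to compound 2 bears on this, since it also exchanged a group holding one five-membered aromatic ring with 3 hetero atoms for the isoquinolin-4-yl group. Moving back toward a five-membered aromatic ring with 2 hetero atoms, the number for compound 3 is expected to move upward by a 2.2-fold higher number from compound 2 to compound 3 (0.35 log units; beyond the scatter), a step of the same order as that measured one. Compound 3 is therefore estimated at 15 nM in this assay, within a range from 5 nM to 50 nM.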

Compound 3, half-maximal inhibitory concentration: 10 nM
Compound 3: middle estimate off by 1.5-fold (0.18 log units), on the high side; measured number inside the range.
By their numbers in this assay, from the lowest: compounds 2 and 3 (each within the scatter of the next); then compound 1.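

The new result shows that a group with a five-membered aromatic ring can serve on this amide-type nitrogen as well as isoquinolin-4-yl: the change gives a 1.5-fold higher number from compound 2 to compound 3 (0.17 log units; within the scatter), so the two cannot be told apart in this assay. It also shows that heavy-atom count alone does not set the number, as replacing one group of 9 heavy atoms with another gives a 2.8-fold lower number from compound 1 to compound 3 (0.45 log units; beyond the scatter), with the five-membered ring going from 3 hetero atoms to 2. Nothing measured here explains either result.

Every group shown on this nitrogen holds two aromatic rings, so it remains open whether a single ring, such as plain phenyl or pyridin-3-yl, would give a similarly low number. As far as these compounds go, how an added amine or carboxylic acid on these groups would shift the number also remains open.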